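Isobutylamino to butylamino: an expected flat step

The compounds below may be only part of what the source reports. "The series", "measured", "known", "first", "only" and "open" are said of these compounds alone.

In a functional assay on HT-29 cells (Homo sapiens) for inhibition, read by sulforhodamine B assay, with a stated time of 72 h (a higher number here means a weaker inhibitor, a lower number a stronger inhibitor), compound 1 `C=CCNC(=C\C(=O)/C=C/c1ccc(O)c(OC)c1)/C=C/c1ccc(O)c(OC)c1` gives 24600 nM and compound 2 `COc1cc(/C=C/C(=O)/C=C(/C=C/c2ccc(O)c(OC)c2)NCC(C)C)ccc1O` gives 24000 nM on the same read-out. Among the compounds with values here, these two values lie within the scatter of each other, so compound 2 cannot be separated from its only measured neighbour.

The next structure, compound 3 `CCCCNC(=C\C(=O)/C=C/c1ccc(O)c(OC)c1)/C=C/c1ccc(O)c(OC)c1`, differs from compound 2 only in the chain on the amine nitrogen: propyl in place of isopropyl on a saturated chain carbon bound to an amine nitrogen. The same difference, cut one bond further out, reads isobutyl to butyl.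

Within the data shown here, one measured step bears on this change, at the same place: a 1.0-fold lower number from compound 1 to compound 2 (0.01 log units; within the scatter). That step put isopropyl in place of vinyl and stayed within the scatter. Among the measured compounds shown here, it is a single step, and the series holds no measured pair of a branched and a straight chain.

No shift beyond the scatter is therefore expected in this assay, and the expected step is a 1.0-fold lower number from compound 2 to compound 3 (0.02 log units; within the scatter) in size. Compound 3 is estimated at 23000 nM, with an expected range from 12000 nM to 42000 nM.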

Compound 3, half-maximal inhibitory concentration: 21200 nM
Estimate against measurement, compound 3: 1.1-fold (0.04 log units) above, and the stated range covers the measured number.
By their numbers in this assay, from the lowest: compounds 3, 2 and 1 (each within the scatter of the next).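

In this assay, within the data shown here, compounds 2 and 3 form the first measured pair of a branched and a straight chain at this place, on a saturated chain carbon bound to an amine nitrogen, and the isobutylamino to butylamino change gives a 1.1-fold lower number from compound 2 to compound 3 (0.05 log units; within the scatter). The second new comparison, a 1.2-fold lower number from compound 1 to compound 3 (0.06 log units; within the scatter), also stays within the scatter, so compounds 1, 2 and 3 cannot be separated at this place, whether the group there is vinyl, isopropyl or propyl. Nothing on hand gives a reason for this flat reading.

The compounds shown leave open how far this flat reading extends, since they cover only small hydrocarbon chains on the nitrogen. A longer chain such as octyl, a benzyl group or a chain ending in a carboxylic acid or a second amine could test whether any group at this place moves the number beyond the scatter.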